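Cyclopentyl in place of methyl on the carbonyl carbon

This account rests on a few compounds, and the source may have more. Where it says the series, first, only, none or still open, it means among the compounds named here.

Measured in a functional assay on A549 cells (Homo sapiens) for cytotoxicity, read by sulforhodamine B assay, with a stated time of 72 h; a lower number here means a stronger inhibitor, a higher number a weaker inhibitor:
compound 1 `CC(=O)Nc1ccn([C@@H]2CO[C@H](CO)O2)c(=O)n1`: 6870 nM
compound 2 `CCCCC(=O)Nc1ccn([C@@H]2CO[C@H](CO)O2)c(=O)n1`: 5230 nM
compound 3 `O=C(Nc1ccn([C@@H]2CO[C@H](CO)O2)c(=O)n1)C1CC1`: 18700 nM

On these numbers compound 1 stands together with compound 2, with a 1.3-fold lower number from compound 1 to compound 2 (0.12 log units; within the scatter). Compound 3 stands apart, with a 2.7-fold higher number from compound 1 to compound 3 (0.43 log units; beyond the scatter).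

The next compound is compound 4 `O=C(Nc1ccn([C@@H]2CO[C@H](CO)O2)c(=O)n1)C1CCCC1`, which differs from compound 1 as follows: cyclopentyl in place of methyl on a carbonyl carbon. Thus cyclopentyl takes the place of methyl on a carbonyl carbon.

Among the compounds with values here, two measured steps bear most directly on this change. Compound 2 carries butyl at that carbon, and its step was within the scatter, a 1.3-fold lower number from compound 1 to compound 2 (0.12 log units; within the scatter). Compound 3 carries cyclopropyl there, and its step was modest, a 2.7-fold higher number from compound 1 to compound 3 (0.43 log units; beyond the scatter). The gap between these two is a 3.6-fold higher number from compound 2 to compound 3 (0.55 log units; beyond the scatter). Compound 4 has a ring like compound 3 but is otherwise unprecedented in this small set, so the two steps give only a loose guide.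

In this assay a small rise at most is therefore expected, and the estimated change is a 1.3-fold higher number from compound 1 to compound 4 (0.12 log units; within the scatter). For compound 4 the estimated value is 9000 nM, with an expected range of 4000 nM to 20000 nM.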

Compound 4, half-maximal inhibitory concentration: 2970 nM
Estimate against measurement, compound 4: 3.0-fold (0.48 log units) above; the measured number lies below the stated range.
By their numbers in this assay, from the lowest: compounds 4, 2 and 1 (each within the scatter of the next, the first and the last beyond it); then compound 3.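

In this assay a ring on the carbonyl carbon does not by itself raise the number: going from acetyl to cyclopentylcarbonyl gives a lower one (a 2.3-fold lower number from compound 1 to compound 4 (0.36 log units; beyond the scatter)), the opposite direction to the earlier cyclopropyl change. Which ring stands at this position therefore matters, as the step between the two rings shows (a 6.3-fold lower number from compound 3 to compound 4 (0.80 log units; beyond the scatter)), while cyclopentyl and the open butyl chain remain within the scatter of each other (a 1.8-fold lower number from compound 2 to compound 4 (0.25 log units; within the scatter)). Nothing at hand accounts for the difference between the two rings.

Whether cyclobutyl or cyclohexyl would follow cyclopropyl or cyclopentyl remains open, since only two ring sizes are shown here. On these data alone, it is also open how a phenyl group or a branched chain such as isopropyl on the carbonyl carbon would compare.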